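Phthalimide-substituted triazole thioethers: cytotoxicity notes

The compounds below may be only part of what the source reports. "The series", "measured", "known", "first", "only" and "open" are said of these compounds alone.

Compound 1 `Cc1nnc(SCC(=O)c2ccc(Cl)cc2)n1N1C(=O)c2ccccc2C1=O`: > 200000 nM in a functional assay on A549 cells (Homo sapiens) for cytotoxicity, read by MTT assay, with a stated time of 48 h (on this read-out lower numbers stand for stronger inhibition and higher numbers for weaker inhibition), a limit.
Compound 2 `CCc1nnc(SCc2ccccc2)n1N1C(=O)c2ccccc2C1=O`: > 200000 nM in this assay, a limit.
Compound 3 `C=CCSc1nnc(-c2cc(OC)c(OC)c(OC)c2)n1N1C(=O)c2ccccc2C1=O`: > 200000 nM in this assay, a limit.

Compound 3 stands nowhere distinct on the numbers shown: its value in this assay is a limit of the method and not a number. Within the data shown here, the same holds for the other two, so the limit of > 200000 nM in this assay, at which 3 of the 3 values shown sit, is all the series gives, and no compound can be set above or below another. Among the measured compounds shown here, no step between measured compounds is available, as no pair differs in one place only.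

Compound 4 `COc1ccc(C(=O)CSc2nnc(-c3cc(OC)c(OC)c(OC)c3)n2N2C(=O)c3ccccc3C2=O)cc1` has not yet been measured in this assay. It differs from compound 3 by (4-methoxyphenyl)carbonyl in place of vinyl on a saturated chain carbon bound to a sulfur; cut one bond further out, the change reads allyl to ((4-methoxyphenyl)carbonyl)methyl, or allylsulfanyl to (((4-methoxyphenyl)carbonyl)methyl)sulfanyl. Compound 1 carries a related aryl-ketone thioether on the same kind of core and gives only a limit, which offers no basis for expecting a change. The expected step of a number no higher from compound 3 to compound 4 (the limit leaves the size open) is therefore none beyond the scatter, with the outcome most likely again a limit. For compound 4 the estimate in this assay is 200000 nM, within 80000 nM to 600000 nM.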

Compound 4, half-maximal inhibitory concentration: 30000 nM
The estimate for compound 4 lay 6.7-fold (0.82 log units) above the measured number; the whole stated range lies above it.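

At the saturated chain carbon bound to a sulfur, the series now shows a change that moves the read-out in this assay: exchanging vinyl for (4-methoxyphenyl)carbonyl gives an at least 6.6-fold lower number from compound 3 to compound 4 (0.82 log units; beyond the scatter). Among these compounds, compound 4, at 30000 nM, supplies the first value that is a number and not a limit of the method, so this position can carry a measurable difference on the shared core. The size of the step remains a lower bound, as compound 3 gives only a limit, and the aromatic ring, the carbonyl and the methoxy group all enter together, so the step cannot be assigned to any one of them.

Still open, on these data alone, is which part of the new group carries the step, and whether an unsubstituted phenyl ketone, a carboxylic acid or a dimethylamino group on the same sulfur-bound chain would give a lower or higher number. Beyond this one pair, the series remains unranked: the limit of > 200000 nM in this assay, at which 3 of the 4 values shown sit.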